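Methyl in place of chloro on the shared core

The source may report more compounds than this note shows. Statements on the series, on what has been measured and on what is new or still open speak of the compounds shown alone.

Measured so far:
compound 1, `COc1ccccc1Sc1c[nH]c2ccc(Cl)cc12`: > 2500 nM, an assay limit rather than a number
compound 2, `COc1cc(Sc2c[nH]c3ccc(Cl)cc23)cc(OC)c1OC`: 77 nM

In a functional assay on MCF7 cells (Homo sapiens) for inhibition, with a stated time of 48 h (on this read-out lower numbers stand for stronger inhibition and higher numbers for weaker inhibition), compound 2 gives 77 nM. Among the measured compounds shown here, this is the only actual number in the set; the one other result is a limit, (the limit of > 2500 nM in this assay, at which 1 of the 2 values shown sits). For the measured compounds named here, for compound 1 the assay reports only that limit, > 2500 nM, so its result is a limit and not a number, and no step between compound 1 and compound 2 can be sized from these two values.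

The next compound, compound 3, `COc1cc(Sc2c[nH]c3ccc(C)cc23)cc(OC)c1OC`, keeps everything of compound 2 except one point: methyl in place of chloro on an aromatic carbon. No measured step of this kind exists among the two compounds shown, so the size and direction of the change in this assay cannot be read from data; a step within the usual scatter, or at most a small one in either direction, is expected.

On that basis compound 3 is estimated at 110 nM, with a range from 35 nM to 350 nM. The expected step is a 1.4-fold higher number from compound 2 to compound 3 (0.15 log units; within the scatter).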

Compound 3, half-maximal inhibitory concentration: 16 nM
The estimate for compound 3 lay 6.9-fold (0.84 log units) above the measured number; measured number below the stated range.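

Methyl in place of chloro gives a 4.8-fold lower number from compound 2 to compound 3 (0.68 log units; beyond the scatter) in this assay, so this position on the six-membered aromatic ring of the shared core responds measurably to the exchange of one heavy atom for another. Chloro is therefore not required here for a low number in this assay, and of the two groups tried at this position, methyl gives the lower number on the otherwise unchanged structure of compound 2. Nothing in the data at hand accounts for the size or the direction of this step.

Only chloro and methyl are shown at this position, so it remains open whether a larger ethyl group, a methoxy group, an amine or a carboxylic acid there would follow the same direction, and whether the same exchange would give a similar step with a different substitution on the other aromatic ring. Among the compounds shown here, compound 1 gives > 2500 nM, which is an assay limit and not a number, so no step involving it can be read.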